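The compounds below may be only part of what the source reports. "The series", "measured", "known", "first", "only" and "open" are said of these compounds alone.

Two compounds set the scene. For compound 1 (`COc1ccc(-c2c(Nc3ccc(F)cc3)c3ccc(OC)cc3oc2=O)cc1`) the result in a functional assay on PANC-1 cells (Homo sapiens) for antiproliferative activity, read by MTT assay, with a stated time of 48 h (on this read-out higher numbers stand for weaker inhibition and lower numbers for stronger inhibition), stands as "not determined" (no result reported) and offers nothing to compare. Within the data shown here, compound 2 (`COc1ccc(Nc2c(C(=O)C(F)(F)F)c(=O)oc3cc(OC)ccc23)cc1`) gives 47500 nM in this assay and this is the only number available, so it has no neighbour to be ranked against. Compound 3 (`COc1ccc2c(Nc3ccc(F)cc3)c(C(=O)C(F)(F)F)c(=O)oc2c1`) has not yet been measured. It departs from compound 2 in one place, and the change is fluoro in place of methoxy on an aromatic carbon with fluoro in place of methoxy on an aromatic carbon, para to a large group, which turns 4-methoxyphenyl into 4-fluorophenyl. Among the measured compounds shown here, no measured pair shows what this swap does, so any expectation remains loose. A small step toward stronger inhibition is expected, possibly none beyond the usual scatter, and the estimated step is a 1.4-fold lower number from compound 2 to compound 3 (0.13 log units; within the scatter) on this view. That expectation is anchored only on compound 2 at 47500 nM and on the structural change itself. Compound 3 is expected at 35000 nM with an estimated range from 12000 nM to 90000 nM as the likely span.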

Compound 3, half-maximal inhibitory concentration: 12200 nM
The estimate for compound 3 lay 2.9-fold (0.46 log units) above the measured number; the range from low to high includes it.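

Among these compounds, the pair of compound 2 and compound 3 is the first to put a size on this change: in this assay, fluoro in place of methoxy on an aromatic carbon, para to a large group, brings a 3.9-fold lower number from compound 2 to compound 3 (0.59 log units; beyond the scatter) and nothing else in the two structures differs. The read-out therefore responds to what sits at this place, and of these two compounds the one carrying the (4-fluorophenyl)amino group is the stronger inhibitor. No measurement shown here accounts for the step, so its cause remains unknown.

With only methoxy and fluoro shown at this place, the compounds leave open whether the step belongs to fluoro itself or simply to the departure of methoxy, a question that chloro, a nitrile or an amine at the same place could help to settle. Also open, as far as these compounds go, is whether the same swap would give a step of similar size on the core of compound 1, which has no reported result, or in another cell line.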